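The source may hold more compounds than are shown below. What is called first, only, known or untested is meant among the compounds shown, and "the series" means these compounds.

Compound 3 `COc1ccc(-c2ccnc(Nc3cccc(OC)c3)n2)cc1` gives 729 nM in an assay on isolated protein for inhibition of phosphatidylinositol 4,5-bisphosphate 3-kinase catalytic subunit beta isoform (Homo sapiens); a higher number here means a weaker inhibitor, a lower number a stronger inhibitor. Going by the values given here, of the three values shown, this is the only one that is a number. Compound 1 `Cc1cccc(Nc2nccc(-c3ccc(Br)cc3)n2)c1` reaches only the limit > 1000 nM in this assay. Compound 2 `COc1cccc(Nc2nccc(-c3ccc(F)cc3)n2)c1` likewise reaches only the limit > 1000 nM in this assay; this is the limit of > 1000 nM in this assay, at which 2 of the 3 values shown sit. Among the compounds with values here, the one measured step, an at least 1.3-fold lower number from compound 2 to compound 3 (0.13 log units; that floor lies within the scatter), sits at its floor within the scatter. The change to compound 4 `COc1cccc(Nc2nccc(-c3ccc(Br)cc3)n2)c1` is bromo in place of methoxy on an aromatic carbon. Within the data shown here, no measured step exchanges methoxy for bromo, so it bears on the present step only indirectly. Compound 1, which carries bromo in the same place, sits at the limit > 1000 nM. Compound 4 is therefore expected near 1500 nM, between 500 nM and 5000 nM. The expected step is a 2.1-fold higher number from compound 3 to compound 4 (0.31 log units; beyond the scatter).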

Compound 4, half-maximal inhibitory concentration: 977 nM
For compound 4 the middle estimate is 1.5-fold (0.19 log units) above the measured one; the measured number falls inside the stated range.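

With bromo or methoxy on this aromatic carbon, para to a large group, the two groups are not separated in this assay: a 1.3-fold higher number from compound 3 to compound 4 (0.13 log units; within the scatter). A bromo compound therefore now has a number at this position, level with the methoxy compound within the scatter. The two other steps, an at least 1.0-fold lower number from compound 2 to compound 4 (0.01 log units; that floor lies within the scatter) and an at least 1.0-fold lower number from compound 1 to compound 4 (0.01 log units; that floor lies within the scatter), start from limits, stop at floors and cannot be read further: the limit of > 1000 nM in this assay, at which 2 of the 4 values shown sit.

Going by these compounds, whether an amine, a carboxylic acid or a longer alkoxy chain at this position would move the number beyond the scatter stays open. On these data alone, the true size of the exchanges of fluoro for bromo and of methyl for methoxy also stays open.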